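The compounds below may be only part of what the source reports. "The series", "measured", "known", "first", "only" and "open" are said of these compounds alone.

Measured compounds in an assay on isolated protein for inhibition of Maltase-glucoamylase (Homo sapiens); on this read-out higher numbers stand for weaker inhibition and lower numbers for stronger inhibition:
Compound 1 `O=c1oc2ccc(Cl)cc2c(O)c1C(c1ccc(Cl)cc1Cl)c1c(O)c2cc(Cl)ccc2oc1=O` gives 16500 nM in this assay.
Compound 2 `COc1cc(C(c2c(O)c3cc(C)ccc3oc2=O)c2c(O)c3cc(C)ccc3oc2=O)cc(OC)c1OC` gives 386000 nM in this assay.
Compound 3 `COc1cc(C(c2c(O)c3cc(Cl)ccc3oc2=O)c2c(O)c3cc(Cl)ccc3oc2=O)ccc1O` gives 83600 nM in this assay.

Compound 3 stands second highest of the three numbers; compound 2 stands higher and compound 1 lower, both beyond the scatter. Within the data shown here, the only single-place step among the measured compounds is a 5.1-fold higher number from compound 1 to compound 3 (0.70 log units; beyond the scatter), which gives a feel for how much the aryl group on the central carbon can move the number in this assay.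

Compound 4 `COc1ccc(C(c2c(O)c3cc(Cl)ccc3oc2=O)c2c(O)c3cc(Cl)ccc3oc2=O)cc1OC` differs from compound 3 only in methyl in place of hydrogen on an oxygen on an aromatic ring. Among the measured compounds shown here, no measured step matches this change: compound 2, which carries three methoxy groups on that ring, also differs from compound 3 on the core, so its higher number cannot be attributed to the methoxy groups alone. What the two values of compound 2 and compound 3 show is that the fully methylated ring sits at the weaker end of the series. From that, compound 4 is expected to give a slightly higher number than compound 3, a step of about a 1.6-fold higher number from compound 3 to compound 4 (0.19 log units; within the scatter), which may well fall within the scatter. Compound 4 is therefore estimated at 130000 nM in this assay, with a range from 50000 nM to 350000 nM.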

Compound 4, half-maximal inhibitory concentration: 91400 nM
The estimate for compound 4 lay 1.4-fold (0.15 log units) above the measured number; low and high end bracket the measured number.
By their numbers in this assay, from the lowest: compound 1; then compounds 3 and 4 (each within the scatter of the next); then compound 2.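

In this assay, among these compounds, methoxy in place of hydroxy on the 4-hydroxy-3-methoxyphenyl ring gives a 1.1-fold higher number from compound 3 to compound 4 (0.04 log units; within the scatter), so on this read-out the hydrogen and the methyl on this oxygen on an aromatic ring cannot be told apart, something the earlier compounds could not show. Replacing the whole aryl group remains the larger change: 3,4-dimethoxyphenyl in place of 2,4-dichlorophenyl gives a 5.5-fold higher number from compound 1 to compound 4 (0.74 log units; beyond the scatter), a step beyond the scatter and similar in size to a 5.1-fold higher number from compound 1 to compound 3 (0.70 log units; beyond the scatter), so both oxygen-bearing rings give higher numbers than the dichlorinated ring. No measurement is available that would explain either step.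

As far as these compounds go, it remains open whether a larger or differently functionalised group on this oxygen, such as a longer chain, an amine or a carboxylic acid, would leave the number equally unchanged. Compound 2 differs from compound 4 both on the aryl ring and on the core, so the separate contributions of these two changes cannot be read.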